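Spiropyrazolone dienone series: removing the para methyl

The compounds below may be only part of what the source reports. "The series", "measured", "known", "first", "only" and "open" are said of these compounds alone.

Measured in a functional assay on HCT-116 cells (Homo sapiens) for antiproliferative activity, read by CCK-8 assay, with a stated time of 72 h; a lower number here means a stronger inhibitor, a higher number a weaker inhibitor:
compound 1 `CC1=NN(c2ccc(Br)cc2)C(=O)C12C=CC(=O)C=C2c1cccc(C)c1`: > 100000 nM, which is a limit of the assay and not a number.
compound 2 `CC1=NN(c2ccccc2)C(=O)C12C=CC(=O)C=C2c1cccc(C)c1`: > 100000 nM, again a limit of the assay.
compound 3 `CC1=NN(c2ccc(C)cc2)C(=O)C12C=CC(=O)C=C2c1ccc(C)cc1`: 9710 nM.

Within the data shown here, compound 3 holds the only number in this assay; the other two values sit at the limit of > 100000 nM in this assay, at which 2 of the 3 values shown sit, so its standing relative to compound 1 and compound 2 cannot be ranked. The step that the two limits leave unreadable from compound 1 to compound 2 is therefore unreadable. Compound 4 `CC1=NN(c2ccc(C)cc2)C(=O)C12C=CC(=O)C=C2c1ccccc1` differs from compound 3 by hydrogen in place of methyl on an aromatic carbon. No measured step touches that ring, so nothing shown bears on this change, and no shift beyond the scatter is expected in this assay. Compound 4 is estimated at 14000 nM (4000 nM to 60000 nM), meaning an expected step of a 1.4-fold higher number from compound 3 to compound 4 (0.16 log units; within the scatter).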

Compound 4, half-maximal inhibitory concentration: 16500 nM
Compound 4: middle estimate off by 1.2-fold (0.07 log units), on the low side; the range from low to high includes it.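

In this assay, among these compounds, the change from 4-methylphenyl to phenyl gives the first readable step, a 1.7-fold higher number from compound 3 to compound 4 (0.23 log units; within the scatter), so this ring position does not need the methyl for the compound to keep a measured value. No information shown gives a cause for this result.

On these data alone, whether an amine, a carboxylic acid or a longer chain at this position would move the value beyond the scatter remains open. The step from compound 1 to compound 2 cannot be read: both values are limits of the assay.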